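A few compounds are considered here, and "the series" means these few. Any claim that something is new, unique, unknown or untested is made for them only; others in the source may bear on it.

Measured compounds in an ADME assay on L02 cells (Homo sapiens) for antiproliferative activity, read by MTT assay, with a stated time of 48 h; on this read-out higher numbers stand for weaker inhibition and lower numbers for stronger inhibition:
- compound 1, `Cc1ccccc1-n1nncc1CN1C(=O)C2(C(C#N)=C(N)Oc3c2c2nc4ccccc4nc2c2ccccc32)c2ccccc21`: compound 1 gives > 50000 nM, which is a limit of the assay and not a number.
- compound 2, `CCOc1ccc(-n2nncc2CN2C(=O)C3(C(C#N)=C(N)Oc4c3c3nc5ccccc5nc3c3ccccc43)c3ccccc32)cc1`: compound 2 gives > 50000 nM, again a limit, not a number.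
- compound 3, `N#CC1=C(N)Oc2c(c3nc4ccccc4nc3c3ccccc23)C12C(=O)N(Cc1cnnn1-c1ccc(N)cc1)c1ccccc12`: compound 3 gives > 50000 nM, also a limit, not a number.

Where compound 2 stands: only a limit is known for it, and the other two values shown are limits as well, all sitting at the limit of > 50000 nM in this assay, at which 3 of the 3 values shown sit. Among the measured compounds shown here, no measured step in the set can therefore be read: a step that the two limits leave unreadable from compound 1 to compound 2, a step that the two limits leave unreadable from compound 1 to compound 3 and a step that the two limits leave unreadable from compound 2 to compound 3 are each left unreadable by the two limits, whatever the change on the aromatic nitrogen (4-ethoxyphenyl, 4-aminophenyl, or amino in place of ethoxy on an aromatic carbon).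

Compound 4, `N#CC1=C(N)Oc2c(c3nc4ccccc4nc3c3ccccc23)C12C(=O)N(Cc1cnnn1-c1cc(Cl)ccc1Cl)c1ccccc12`, is not yet measured. It differs from compound 2 as follows: 2,5-dichlorophenyl in place of 4-ethoxyphenyl on an aromatic nitrogen.

For the measured compounds named here, the steps that bear on this change, 1>2, 1>3 and 2>3, all vary the group on the same aromatic nitrogen and all run from one limit to another, so no size is available for any of them. On that basis no step beyond the scatter is expected in this assay, and the most likely outcome for compound 4 is again a limit. The step from compound 2 to compound 4 is estimated as a step that the limit leaves unreadable from compound 2 to compound 4. Compound 4 is expected at 60000 nM, within 30000 nM to 150000 nM.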

Compound 4, half-maximal inhibitory concentration: > 50000 nM
Compound 4: only a limit was reported; the forecaster's own chance of this, stated with the estimate: 85%; the middle value lies beyond the limit too.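

In this assay, among the compounds shown here, compound 4 gives > 50000 nM, a limit and not a number, so no step from compound 1, compound 2 or compound 3 to compound 4 can be read: the limit of > 50000 nM in this assay, at which 4 of the 4 values shown sit.

The compounds shown leave open what size of effect, if any, a change of the group on the aromatic nitrogen has on this read-out, as none of them gives a value inside the measurable range.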